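Toward compound 3: trading a chlorobenzyl for a chlorophenyl amide

The compounds below may be only part of what the source reports. "The series", "measured", "known", "first", "only" and "open" are said of these compounds alone.

This account concerns two measured compounds and one still awaiting a number. In an ADME assay on HepG2 cells (Homo sapiens) for cytotoxicity, with a stated time of 3 days (a lower number here means that less compound is tolerated, a higher number that more compound is tolerated), compound 1, with the structure `O=C(CCSc1nnc(-c2ccncc2)s1)Nc1ccc(Cl)cc1`, gives 7260 nM. Compound 2, with the structure `CC(CSc1nnc(-c2ccncc2)s1)C(=O)NCc1ccccc1Cl`, is known in this assay only as a limit, at > 50000 nM, which is the limit of > 50000 nM in this assay, at which 1 of the 2 values shown sits. Compound 3, with the structure `CC(CSc1nnc(-c2ccncc2)s1)C(=O)Nc1ccc(Cl)cc1`, has not yet been measured. It differs from compound 2 by 4-chlorophenyl in place of 2-chlorobenzyl on an amide-type nitrogen. Compound 3 thus carries the same amide partner as compound 1 while keeping the branched chain of compound 2, so a position somewhere between the two measured compounds is expected. From the limit of compound 2 a step downward in this assay is expected, of the size an at least 2.5-fold lower number from compound 2 to compound 3 (0.39 log units; beyond the scatter), though its true extent cannot be fixed from a limit. The estimate for compound 3 is 20000 nM, within the range 7000 nM to 60000 nM.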

Compound 3, half-maximal cytotoxic concentration: > 50000 nM
Compound 3: no number, only a limit; the forecaster's own chance of this, stated with the estimate: 35%; at least 2.5-fold (0.39 log units) between middle value and limit.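

In this assay, methyl in place of hydrogen on the saturated chain carbon bound to a carbonyl carbon and a saturated chain carbon, with the 4-chlorophenyl amide held constant, gives an at least 6.8-fold higher number from compound 1 to compound 3 (0.83 log units; beyond the scatter). Within the data shown here, compound 1 and compound 2 differ in more than one place, so this pair is the first to isolate that methyl, and the change it carries lies beyond the usual scatter. The exchange of 2-chlorobenzyl for 4-chlorophenyl on the amide-type nitrogen cannot be read, because compound 2 and compound 3 are both known only as a limit: the limit of > 50000 nM in this assay, at which 2 of the 3 values shown sit.

From the compounds shown here alone, the true size of the methyl step remains open, as does any difference between the two amide partners on the branched chain. Also open, going by these compounds, is whether an ethyl group or a hydroxyl group in place of that methyl would give a similar result.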